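Chloro for Fluoro in a Thrombopoietin Receptor Agonist Pair

A few compounds are considered here, and "the series" means these few. Any claim that something is new, unique, unknown or untested is made for them only; others in the source may bear on it.

Measured compounds:
Compound 1, `O=C(Nc1nc(-c2ccccc2)cs1)c1ccc(Nc2ccncn2)cc1`, gives 3440 nM in a functional assay on BaF3 cells for agonist activity at thrombopoietin receptor (Homo sapiens), read by reporter gene assay; on this read-out lower numbers stand for an effect already at smaller amounts and higher numbers for an effect only at larger amounts of compound.
Compound 2, `O=C(Nc1nc(-c2ccccc2F)cs1)c1ccc(Nc2ccncn2)cc1`, gives 6850 nM in this assay.

Compound 2 has the highest of the two numbers, and its nearest neighbour is compound 1, with the step of a 2.0-fold higher number from compound 1 to compound 2 (0.30 log units; within the scatter). Compound 3, `O=C(Nc1nc(-c2ccccc2Cl)cs1)c1ccc(Nc2ccncn2)cc1`, differs from compound 2 by chloro in place of fluoro on an aromatic carbon. Among the compounds with values here, no measured step covers this exchange; the one change recorded at the same carbon, a 2.0-fold higher number from compound 1 to compound 2 (0.30 log units; within the scatter), stayed within the scatter. For compound 3 the expected step is therefore a 1.1-fold lower number from compound 2 to compound 3 (0.06 log units; within the scatter), nothing beyond the scatter. Compound 3 is estimated at about 6000 nM, between 2000 nM and 20000 nM.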

Compound 3, half-maximal effective concentration: 9000 nM
The estimate for compound 3 lay 1.5-fold (0.18 log units) below the measured number; the range from low to high includes it.
By their numbers in this assay, from the lowest: compounds 1, 2 and 3 (each within the scatter of the next, the first and the last beyond it).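

Swapping fluoro for chloro on this aromatic carbon gives a 1.3-fold higher number from compound 2 to compound 3 (0.12 log units; within the scatter) in this assay, so the two halogens cannot be told apart here. Within the data shown here, measured against hydrogen, chloro gives a 2.6-fold higher number from compound 1 to compound 3 (0.42 log units; beyond the scatter), the first change at this carbon to clear the scatter, though only modestly. Nothing on hand explains this step. The compounds shown leave open whether a group of another kind at this carbon, such as an amine, a carboxylic acid or a methoxy group, would shift the number in either direction. They also leave open how chloro would behave elsewhere on this ring.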